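The source may report more compounds than this note shows. Statements on the series, on what has been measured and on what is new or still open speak of the compounds shown alone.

Measured compounds in a functional assay on DU-145 cells (Homo sapiens) for cytotoxicity, read by MTT assay; on this read-out lower numbers stand for stronger inhibition and higher numbers for weaker inhibition:
compound 1, `CC(C)=CC[C@@H](OC(=O)c1ccco1)C1=CC(=O)c2c(O)ccc(O)c2C1=O`, > 100000 nM (a limit of the assay, not a number)
compound 2, `CC(C)=CC[C@@H](OCCO)C1=CC(=O)c2c(O)ccc(O)c2C1=O`, 9900 nM
compound 3, `CC(C)=CC[C@@H](OCC(C)O)C1=CC(=O)c2c(O)ccc(O)c2C1=O`, 16100 nM

Compound 1 stands at the weak end of these three: its value is only a limit, so its true number is not known. Compound 4, `CCCCCCC(C)(O)CC(=O)O[C@H](CC=C(C)C)C1=CC(=O)c2c(O)ccc(O)c2C1=O`, differs from compound 1 by 2-hydroxy-2-methyloctyl in place of furan-2-yl on a carbonyl carbon. Within the data shown here, the steps that bear on this change both start from compound 1 and replace the (furan-2-yl)carbonyl on an oxygen on a saturated carbon: an at least 10-fold lower number from compound 1 to compound 2 (1.00 log units; beyond the scatter) and an at least 6.2-fold lower number from compound 1 to compound 3 (0.79 log units; beyond the scatter). In compound 4 the carbonyl remains and a 2-hydroxy-2-methyloctyl group with one hydrogen-bond donor enters, so a smaller gain than in those steps is expected. Compound 4 is expected at 40000 nM, between 8000 nM and 200000 nM, which would be an at least 2.5-fold lower number from compound 1 to compound 4 (0.39 log units; beyond the scatter).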

Compound 4, half-maximal inhibitory concentration: > 100000 nM
Compound 4: a limit, no number (the forecaster's own chance of this, stated with the estimate: 40%); at least 2.5-fold (0.39 log units) between middle value and limit.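

Compound 1 and compound 4 both give a limit rather than a number, so no step can be read between them: the limit of > 100000 nM in this assay, at which 2 of the 4 values shown sit.

The compounds shown leave open whether 2-hydroxy-2-methyloctyl in place of furan-2-yl changes the activity at all, and by how much.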